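Closing the Side Chain into a Cyclopropane Ring

This account rests on a few compounds, and the source may have more. Where it says the series, first, only, none or still open, it means among the compounds named here.

Compound 2 `COC(C(=O)O)c1nn(Cc2cn3cc(OCC4CC4)c(Cl)cc3n2)c2ccccc2c1=O` gives the highest of the two numbers measured in a functional assay on CHO cells for antagonist activity at sphingosine 1-phosphate receptor 2 (Homo sapiens), read by calcium flux (on this read-out higher numbers stand for weaker inhibition and lower numbers for stronger inhibition), at 23 nM. Its nearest neighbour, compound 1 `CC(C(=O)O)c1nn(Cc2cn3cc(OCC4CC4)c(Cl)cc3n2)c2ccccc2c1=O`, gives 6 nM in this assay. Compound 3 `O=C(O)C1(c2nn(Cc3cn4cc(OCC5CC5)c(Cl)cc4n3)c3ccccc3c2=O)CC1` differs from compound 2 in one place: 1-carboxycyclopropyl in place of carboxy(methoxy)methyl on an aromatic carbon. Among the compounds with values here, no measured step covers this change directly; the only step at hand, a 3.8-fold higher number from compound 1 to compound 2 (0.58 log units; beyond the scatter), removed the methyl and brought in the methoxy that now leaves. Compound 3 is therefore expected to show a lower number in this assay, by about a 2.3-fold lower number from compound 2 to compound 3 (0.36 log units; beyond the scatter). The estimate for compound 3 is 10 nM, within a range of 3 nM to 40 nM.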

Compound 3, half-maximal inhibitory concentration: 16 nM
Beside the measured number, compound 3's estimate is 1.6-fold (0.20 log units) below it; the measured number falls inside the stated range.
By their numbers in this assay, from the lowest: compound 1; then compounds 3 and 2 (each within the scatter of the next).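

In this assay, 1-carboxycyclopropyl in place of carboxy(methoxy)methyl gives a 1.4-fold lower number from compound 2 to compound 3 (0.16 log units; within the scatter) and so does not separate the two groups at this position. Set against 1-carboxyethyl, the same ring gives a 2.7-fold higher number from compound 1 to compound 3 (0.43 log units; beyond the scatter) and so does not match the number of the methyl-bearing compound 1. Nothing at hand explains either step. The compounds shown leave open how an amide in place of the carboxylic acid, or an ethyl chain on the same saturated carbon, would read out at this position.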